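Replacing the furoyl group of compound 1 with pyridinyl

A few compounds are considered here, and "the series" means these few. Any claim that something is new, unique, unknown or untested is made for them only; others in the source may bear on it.

Compound 1 `CC1(C)C=C(n2ccccc2=O)c2cc(C(=O)c3ccco3)ccc2O1` carries a (furan-2-yl)carbonyl group on its core. In a functional assay (trachea) with Rattus norvegicus as the target (on this read-out higher numbers stand for higher potency (the scale is a negative logarithm) and lower numbers for lower potency), compound 1 gives 5.92, the second highest of the three numbers measured. Its nearest neighbour is compound 2 `CC1(C)C=C(n2ccccc2=O)c2cc(C(=O)c3ccc([N+](=O)[O-])cc3)ccc2O1`, which gives 6.09, and the step of a number 0.17 log units higher from compound 1 to compound 2 (within the scatter) lies within the scatter. Compound 3 `CC1(C)C=C(n2ccccc2=O)c2cc(C(=O)c3ccccc3[N+](=O)[O-])ccc2O1` gives 5.64; the step of a number 0.28 log units lower from compound 1 to compound 3 (within the scatter) is also within the scatter, while the step of a number 0.45 log units lower from compound 2 to compound 3 (beyond the scatter) is modest but beyond it. All three compounds keep the carbonyl and differ only in the aromatic ring attached to it, so these numbers show that swapping that ring moves potency little.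

Compound 4 `CC1(C)C=C(n2ccccc2=O)c2cc(-c3ccncc3)ccc2O1` differs from compound 1 in another way. pyridin-4-yl in place of (furan-2-yl)carbonyl on an aromatic carbon The carbonyl leaves together with the furan, and a pyridin-4-yl ring sits directly on the aromatic carbon. Among the measured compounds shown here, no measured step removes the carbonyl, so the three steps bear on this change only loosely, by showing that the group at this place tolerates variation without large shifts. On that basis a step of about a number 0.02 log units lower from compound 1 to compound 4 (within the scatter) is expected, small enough to fall within the scatter. For the measured compounds named here, compound 4 is therefore expected to give 5.9 in this assay, with a range from 5.2 to 6.6; the range is wide, since no measured step covers the loss of the carbonyl.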

Compound 4, logarithm of the reciprocal of the active concentration, log(1/C): 6.32
The estimate for compound 4 lay 0.42 log units below the measured number, and the stated range covers the measured number.
By their numbers in this assay, from the lowest: compounds 3, 1, 2 and 4 (each within the scatter of the next, the first and the last beyond it).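

Among the compounds shown here, compound 4 is the first compound here to lose the carbonyl, and this change gives a number 0.40 log units higher from compound 1 to compound 4 (beyond the scatter) in this assay, so at this place on the core the carbonyl is not needed to keep potency. A pyridin-4-yl ring sitting directly on the aromatic carbon is tolerated at least as well as the (furan-2-yl)carbonyl group, and this step, though modest, clears the scatter, whereas the steps from compound 1 to compounds 2 and 3, which keep the carbonyl, stay within it. Nothing given here bears on why the number rises, so the result stands as an observation without an explanation.

Two things changed at once in this step, the carbonyl left and the furan gave way to pyridine, so the compounds shown cannot say how much of the rise belongs to each. A phenyl ring placed directly on the same aromatic carbon, or a pyridin-4-yl ring held on a carbonyl, would help to pull these two changes apart.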